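Swapping the aromatic group on a shared core

The source may report more compounds than this note shows. Statements on the series, on what has been measured and on what is new or still open speak of the compounds shown alone.

Measured so far in a functional assay on HCT-116 cells (Homo sapiens) for antiproliferative activity, read by MTT assay (on this read-out lower numbers stand for stronger inhibition and higher numbers for weaker inhibition), are three compounds.
Compound 1 `Cn1c(=O)c(=O)n(C2CCCC2)c2nc(N/N=C/c3ccc(F)c(Cl)c3)ncc21` gives 9020 nM
Compound 2 `Cn1c(=O)c(=O)n(C2CCCC2)c2nc(N/N=C/c3ccc(C(F)(F)F)cc3)ncc21` gives 29000 nM
Compound 3 `Cn1c(=O)c(=O)n(C2CCCC2)c2nc(N/N=C/c3cccc(Cl)c3Cl)ncc21` gives 26400 nM

Compound 3 cannot be told apart from compound 2 (a 1.1-fold lower number from compound 2 to compound 3 (0.04 log units; within the scatter)) and lies above compound 1 (a 2.9-fold higher number from compound 1 to compound 3 (0.47 log units; beyond the scatter)) on this scale. Compound 4 `Cc1cc(C)c(/C=N/Nc2ncc3c(n2)n(C2CCCC2)c(=O)c(=O)n3C)c(C)c1` has not been measured. In it, 2,4,6-trimethylphenyl takes the place of 2,3-dichlorophenyl on a carbon with a double bond to nitrogen (2,4,6-trimethylphenyl in place of 2,3-dichlorophenyl on a carbon with a double bond to nitrogen). Earlier swaps at this same place gave modest steps (a 3.2-fold higher number from compound 1 to compound 2 (0.51 log units; beyond the scatter) and a 2.9-fold higher number from compound 1 to compound 3 (0.47 log units; beyond the scatter)) or none beyond the scatter (a 1.1-fold lower number from compound 2 to compound 3 (0.04 log units; within the scatter)). Within the data shown here, no measured compound carries the new group, so the direction stays open. The expected result in this assay is a 1.2-fold lower number from compound 3 to compound 4 (0.08 log units; within the scatter) and thus no clear change. Compound 4 is estimated at 22000 nM with an expected range from 9000 nM to 50000 nM in this measurement.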

Compound 4, half-maximal inhibitory concentration: 7920 nM
Beside the measured number, compound 4's estimate is 2.8-fold (0.44 log units) above it; measured number outside the range, below it.
By their numbers in this assay, from the lowest: compounds 4 and 1 (each within the scatter of the next); then compounds 3 and 2 (each within the scatter of the next).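

In this assay, 2,4,6-trimethylphenyl gives a clear improvement over two of the earlier groups at this place, with a 3.3-fold lower number from compound 3 to compound 4 (0.52 log units; beyond the scatter) and a 3.7-fold lower number from compound 2 to compound 4 (0.56 log units; beyond the scatter). Against 3-chloro-4-fluorophenyl there is no real difference, with a 1.1-fold lower number from compound 1 to compound 4 (0.06 log units; within the scatter), so a group with carbon atoms only can do as well here as the best halogen-bearing group shown. No measurement shown explains these steps. On these data alone, how a phenyl group carrying an amine or a carboxylic acid, or plain unsubstituted phenyl, would behave at this place remains open.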